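The source may hold more compounds than are shown below. What is called first, only, known or untested is meant among the compounds shown, and "the series" means these compounds.

Measured so far:
compound 1, `N#CC1=C(N)N(c2ccc(S(N)(=O)=O)cc2)C2=C(C(=O)CCC2)C1c1ccccc1`: 40%
compound 2, `N#CC1=C(N)N(c2ccc(S(N)(=O)=O)cc2)C2=C(C(=O)CCC2)C1c1c(O)ccc2ccccc12`: 15%

Among the measured compounds shown here, compound 2 has the lower of the two numbers in a functional assay on Ehrlich cells (Mus musculus) for antiproliferative activity, read by trypan blue exclusion, with a stated time of 2 h, tested at 100 ug/mL; on this read-out higher numbers stand for a stronger effect at the one concentration tested and lower numbers for a weaker effect; its only neighbour is compound 1, which sits a number 25 percentage points lower from compound 1 to compound 2 (beyond the scatter). That single step is the only one known, and it swaps a phenyl for a 2-hydroxynaphthalen-1-yl.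

Compound 3, `COc1ccc(C2C(C#N)=C(N)N(c3ccc(S(N)(=O)=O)cc3)C3=C2C(=O)CCC3)c2ccccc12`, differs from compound 2 as follows: 4-methoxynaphthalen-1-yl in place of 2-hydroxynaphthalen-1-yl on a saturated ring carbon. Both compounds carry a naphthalen-1-yl on the saturated ring carbon, so the step from compound 1 to compound 2 does not bear directly on this change; it only shows that the group at this position can move the number by a modest amount. For the measured compounds named here, no measured step tells whether exchanging the hydroxyl for a methoxy, at a different position of the naphthalene, shifts the read-out in either direction. Compound 3 is therefore expected to stay near compound 2, with an expected step of a number 7 percentage points higher from compound 2 to compound 3 (within the scatter), not beyond the scatter. The estimate for compound 3 in this assay is 22%, within a range from 5% to 45%.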

Compound 3, a percentage reported as activity, at one concentration (the size of the read-out at that concentration, not a potency): 90%
Beside the measured number, compound 3's estimate is 68 percentage points below it; measured number above the stated range.
By their numbers in this assay, from the lowest: compound 2; then compound 1; then compound 3.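

The change from 2-hydroxynaphthalen-1-yl to 4-methoxynaphthalen-1-yl brings a number 75 percentage points higher from compound 2 to compound 3 (beyond the scatter) in this assay and shows that this position can move the number much further than the first step suggested. The step of a number 50 percentage points higher from compound 1 to compound 3 (beyond the scatter) also sets a naphthalen-1-yl group above phenyl, whereas compound 2 had stood below it, so a naphthalen-1-yl at this saturated ring carbon does not by itself lower the number: the outcome depends on what the naphthalene carries and where. Nothing shown here explains why the number moves so far.

The hydroxyl and the methoxy differ both as groups and in where they sit, so the compounds shown cannot separate the two changes, and only a pair such as 2-methoxynaphthalen-1-yl or 4-hydroxynaphthalen-1-yl would do so. From the compounds shown here alone, it also remains open whether the large rise needs the second aromatic ring at all, as 4-methoxyphenyl would test, or whether another group at the same place on the naphthalene, such as an amine or an ethoxy, would give a similar number.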